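Methoxy for methyl: a second look at one substitution

A few compounds are considered here, and "the series" means these few. Any claim that something is new, unique, unknown or untested is made for them only; others in the source may bear on it.

Measured compounds:
compound 1, `COc1ccc(C(N)=O)cc1/C=C/c1ccc(C)cc1`: 1600 nM
compound 2, `COc1ccc(/C=C/c2cc(C(N)=O)ccc2OC)cc1`: 8800 nM
compound 3, `COc1ccc(C(N)=O)cc1/C=C/c1ccccc1C`: 2300 nM

In a functional assay on HUVEC cells (Homo sapiens) for inhibition, with a stated time of 4 days (on this read-out higher numbers stand for weaker inhibition and lower numbers for stronger inhibition), compound 1 gives 1600 nM, compound 2 gives 8800 nM, and compound 3 gives 2300 nM. Compound 1 and compound 3 have the same atoms joined differently; the difference between the two cores is not broken down here, and their values lie within the scatter of each other. Compound 2 differs from compound 1 by methoxy in place of methyl on an aromatic carbon, and this change produced a 5.5-fold higher number from compound 1 to compound 2 (0.74 log units; beyond the scatter).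

Compound 4, `COc1ccccc1/C=C/c1cc(C(N)=O)ccc1OC`, has not yet been measured. It differs from compound 3 by methoxy in place of methyl on an aromatic carbon. This is the same kind of change as that from compound 1 to compound 2, but not the same: there the place is para to a large group, here it is ortho to a large group. Among the compounds with values here, the single measured instance is the only guide. On that basis, a step of a 3.9-fold higher number from compound 3 to compound 4 (0.59 log units; beyond the scatter) is expected in this assay for compound 4, because compound 1 to compound 2 gave a 5.5-fold higher number from compound 1 to compound 2 (0.74 log units; beyond the scatter). Compound 4 is therefore estimated at 9000 nM, with a range from 3500 nM to 25000 nM.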

Compound 4, half-maximal inhibitory concentration: 5700 nM
Beside the measured number, compound 4's estimate is 1.6-fold (0.20 log units) above it, and the stated range covers the measured number.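

In this assay, methoxy in place of methyl on an aromatic carbon again weakened inhibition, giving a 2.5-fold higher number from compound 3 to compound 4 (0.39 log units; beyond the scatter). Set beside the earlier case, the two steps point the same way and their sizes cannot be told apart: the same change on two cores in this assay, a 5.5-fold higher number (0.74 log units; beyond the scatter) from compound 1 to compound 2 and a 2.5-fold higher number (0.39 log units; beyond the scatter) from compound 3 to compound 4, 2.2-fold (0.35 log units) apart, within the scatter of two such steps. This suggests that the direction and rough size of the change carried over between these two cores, but two pairs are too few to show that it would hold on any other core, and they cannot separate the influence of the core from that of the place, which for the new step is ortho to a large group.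

The compounds shown leave open how an amine, a hydroxyl group or a fluorine on the same aromatic carbon would compare with methyl and methoxy. They also leave open whether the step would keep its direction if a carboxylic acid or a nitrile stood in place of the amide.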